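This account rests on a few compounds, and the source may have more. Where it says the series, first, only, none or still open, it means among the compounds named here.

Working notes on the series in an ADME assay on HEK-293T cells (Homo sapiens) for cytotoxicity, read by CCK-8 assay, with a stated time of 48 h; on this read-out lower numbers stand for stronger inhibition and higher numbers for weaker inhibition. Here compound 2 `O=C(Nc1ccc(F)cc1)N1CCN(S(=O)(=O)c2sccc2-c2ccccc2Oc2ccc(O)c(O)c2)CC1` gives 15500 nM, the only actual number so far. Compound 1 `Cc1ccc(-c2ccsc2S(=O)(=O)NCCNC(=O)Nc2cc(C(F)(F)F)cc(C(F)(F)F)c2)c(Oc2ccc(O)c(O)c2)c1` reads > 20000 nM, which is a limit of the assay. Compound 3 `COc1ccc(Oc2ccccc2-c2ccsc2S(=O)(=O)N2CCN(C(=O)Nc3ccc(F)cc3)CC2)cc1OC` reads > 50000 nM, which is also a limit.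

The next structure is compound 4 `O=S(=O)(c1sccc1-c1ccccc1Oc1ccc(O)c(O)c1)N1CCN(C(=S)Nc2ccc(Cl)cc2)CC1`, and its difference from compound 2 is a group of 10 heavy atoms (7 carbon, 1 nitrogen, 1 sulfur, 1 chlorine; one six-membered aromatic ring of carbon only) in place of a group of 10 heavy atoms (7 carbon, 1 nitrogen, 1 oxygen, 1 fluorine; one six-membered aromatic ring of carbon only), on an amine nitrogen in a ring. The (4-fluorophenyl)carbamoyl group leaves the amine nitrogen in a ring, and the 3,4-dihydroxyphenyl group stays.

Within the data shown here, the one measured step, an at least 3.2-fold higher number from compound 2 to compound 3 (0.50 log units; beyond the scatter), exchanges 3,4-dihydroxyphenyl for 3,4-dimethoxyphenyl, a change at another place that compound 4 does not share. Among the measured compounds shown here, no measured step touches the amine nitrogen in a ring, so the data give no direction for this change. The expected step in this assay is therefore none beyond the scatter: a 1.2-fold lower number from compound 2 to compound 4 (0.08 log units; within the scatter). For compound 4 the estimated value is 13000 nM, with an expected range of 5500 nM to 30000 nM.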

Compound 4, half-maximal inhibitory concentration: > 50000 nM
Compound 4 was reported as a limit (the forecaster's own chance of this, stated with the estimate: 15%); at least 3.8-fold (0.58 log units) between middle value and limit.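

In this assay the amine nitrogen in a ring now has its first measured step, and it is beyond the scatter: an at least 3.2-fold higher number from compound 2 to compound 4 (0.50 log units; beyond the scatter). Changes at two separate places on compound 2 have now each given a step beyond the scatter, and compound 4 keeps the 3,4-dihydroxyphenyl group, so that group alone does not fix the reading in this series. The value of compound 4 is a limit and not a number, and it is shared with another compound in the series: the limit of > 50000 nM in this assay, at which 2 of the 4 values shown sit.

The entering group differs from the (4-fluorophenyl)carbamoyl group in both sulfur for oxygen and chlorine for fluorine, so the compounds shown do not say which exchange carries the step. A (4-chlorophenyl)carbamoyl group on the same amine nitrogen would separate the two.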